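Swapping the benzyl on compound 2 for dinitrophenyl

This account rests on a few compounds, and the source may have more. Where it says the series, first, only, none or still open, it means among the compounds named here.

Compound 1 `O=S(=O)(NCCNC(=S)Nc1cccc(Cl)c1)c1ccc(-c2ccccc2OCc2ccccc2)s1` in a functional assay on HeLa cells (Homo sapiens) for inhibition, read by CCK-8 assay, with a stated time of 48 h (on this read-out higher numbers stand for weaker inhibition and lower numbers for stronger inhibition), gives 8400 nM. Compound 3 `O=[N+]([O-])c1cccc(NC(=S)NCCNS(=O)(=O)c2ccc(-c3ccccc3OCc3ccccc3)s2)c1` in this assay gives 12800 nM, and between the two there is a 1.5-fold higher number from compound 1 to compound 3 (0.18 log units; within the scatter). For compound 2 `COc1cccc(NC(=O)NCCNS(=O)(=O)c2ccc(-c3ccccc3OCc3ccccc3)s2)c1` this assay reports only a limit of the assay, > 50000 nM. That value sits at the limit of > 50000 nM in this assay, at which 1 of the 3 values shown sits. The steps that link it to the others are an at least 5.9-fold higher number from compound 1 to compound 2 (0.77 log units; beyond the scatter) and an at least 3.9-fold lower number from compound 2 to compound 3 (0.59 log units; beyond the scatter).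

Compound 4 `COc1cccc(NC(=O)NCCNS(=O)(=O)c2ccc(-c3ccccc3Oc3ccc([N+](=O)[O-])c([N+](=O)[O-])c3)s2)c1` differs from compound 2 in a different place: 3,4-dinitrophenyl in place of benzyl on an oxygen on an aromatic ring. All three measured steps alter the group on the amine nitrogen and leave the oxygen on the aromatic ring untouched, so none of them bears on this change, and neither a direction nor a size of step can be read from them. Since compound 2 itself stands at the limit, compound 4 is expected to give 50000 nM, with a range from 15000 nM to 200000 nM, and most likely again only as a limit. The step expected is a number no higher from compound 2 to compound 4 (the limit leaves the size open).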

Compound 4, half-maximal inhibitory concentration: > 20000 nM
Compound 4: a limit, no number; the forecaster's own chance of this, stated with the estimate: 65%; the middle value is on the limit's open side.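

In this assay compound 4 gives > 20000 nM, which is a limit and not a number. For the compounds shown here, compound 2 also stands only as a limit, so no step between compound 2 and compound 4 can be read. From the compounds shown here alone, whether 3,4-dinitrophenyl in place of benzyl changes inhibition at all, and in which direction, stays open.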